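The compounds below may be only part of what the source reports. "The series", "measured", "known", "first", "only" and "open" are said of these compounds alone.

Series notes. The shared core of compound 1 `CN(C[C@H]1Cc2c(cccc2N2CCN3CCC[C@H]3C2)CN1)[C@H]1CCCc2cccnc21` carries a saturated bicyclic diamine on an aromatic carbon; in a functional assay on CCRF-CEM cells for agonist activity at C-X-C chemokine receptor type 4 (Homo sapiens), read by calcium flux, with a stated time of 25 min (a higher number here means that more compound is needed for the effect, a lower number that less compound is needed), compound 1 gives > 30000 nM, which is a limit of the assay and not a number. Compound 2 `FC1(F)CCC(CN(C[C@H]2Cc3c(cccc3N3CCNCC3)CN2)[C@H]2CCCc3cccnc32)CC1` gives > 30000 nM in this assay, again a limit. Compound 3 `CCCN(C[C@H]1Cc2c(cccc2N2CCNCC2)CN1)[C@H]1CCCc2cccnc21` gives > 30000 nM in this assay, also a limit. Among the compounds with values here, the only step between measured neighbours, a step that the two limits leave unreadable from compound 2 to compound 3, is unreadable in size, both of its ends being limits. Every value shown sits at the limit of > 30000 nM in this assay, at which 3 of the 3 values shown sit, so nothing in the measured set is readable as a step, and compound 1 stands at that limit together with the other two.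

Compound 4 `CN(C[C@H]1Cc2c(cccc2N2C[C@H]3C[C@@H]2CN3)CN1)[C@H]1CCCc2cccnc21` differs from compound 1 by a group of 7 heavy atoms (5 carbon, 2 nitrogen; 2 five-membered non-aromatic rings with 1 hetero atom each) in place of a group of 9 heavy atoms (7 carbon, 2 nitrogen; one five-membered non-aromatic ring with 1 hetero atom, one six-membered non-aromatic ring with 2 hetero atoms), on an aromatic carbon. Within the data shown here, no measured step bears on this change: the single step available concerns the other amine of the core and carries no readable size. With the three measured compounds all at the limit and nothing to set a direction, the step from compound 1 to compound 4 is expected to be a number no higher from compound 1 to compound 4 (the limit leaves the size open), that is, no move beyond the scatter. Compound 4 is therefore estimated to give 30000 nM in this assay, within a range from 10000 nM to 100000 nM, most probably reported once more as a limit.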

Compound 4, half-maximal effective concentration: > 30000 nM
Compound 4 was reported as a limit (the forecaster's own chance of this, stated with the estimate: 85%); the middle value sits exactly at the limit.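

Compound 1 and compound 4 are both reported as limits of the assay and not as numbers, so the step between them cannot be read and no new step follows: the limit of > 30000 nM in this assay, at which 4 of the 4 values shown sit.

The compounds shown leave open which change to the shared core, if any, would give a readable number in this assay.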